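This account rests on a few compounds, and the source may have more. Where it says the series, first, only, none or still open, it means among the compounds named here.

Compound 1 `COc1ccc2c(c1)CCC/C2=N\NCc1nc2ccccc2[nH]1`, in a functional assay on HCT-116 cells (Homo sapiens) for cytotoxicity, read by MTT assay; a higher number here means a weaker inhibitor, a lower number a stronger inhibitor: 41000 nM
Compound 2 `O=[N+]([O-])c1ccc2[nH]c(CNc3nc4ccc(F)cc4s3)nc2c1`: 253000 nM
Compound 3 `COc1ccc2c(c1)CCC/C2=N\NCc1nc2cc([N+](=O)[O-])ccc2[nH]1`: 45000 nM

Compound 1 and compound 3 share one core and differ only by hydrogen in place of nitro on an aromatic carbon; the measured step here is a 1.1-fold lower number from compound 3 to compound 1 (0.04 log units; within the scatter). Compound 2 is built on another core, and how that core differs from the core of compound 3 is not broken down here. Compound 4 `Fc1ccc2nc(NCc3nc4ccccc4[nH]3)sc2c1` has not yet been measured. Going by the values given here, it differs from compound 2 by hydrogen in place of nitro on an aromatic carbon, the same change as the one from compound 3 to compound 1. The step expected from compound 2 to compound 4 in this assay is therefore a 1.1-fold lower number from compound 2 to compound 4 (0.04 log units; within the scatter), and this rests on compound 3 and compound 1, because a 1.1-fold lower number from compound 3 to compound 1 (0.04 log units; within the scatter) stayed within the scatter. Compound 4 is accordingly estimated to give 230000 nM, somewhere between 100000 nM and 500000 nM.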

Compound 4, half-maximal inhibitory concentration: 238000 nM
Estimate against measurement, compound 4: 1.0-fold (0.01 log units) below, within the range that was stated.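

In this assay, hydrogen in place of nitro on the second core gives a 1.1-fold lower number from compound 2 to compound 4 (0.03 log units; within the scatter), and this can be set beside the same change on the first core: the same change on two cores in this assay, a 1.1-fold lower number (0.04 log units; within the scatter) from compound 3 to compound 1 and a 1.1-fold lower number (0.03 log units; within the scatter) from compound 2 to compound 4, 1.0-fold (0.01 log units) apart, within the scatter of two such steps

On both cores, then, removing the nitro group made no measurable difference, and in that limited sense the result carried over from one core to the other. This does not show that the two cores respond alike to every change, as two steps within the scatter are only two cases of no visible effect, and they say nothing about how a larger effect would carry over.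

The compounds shown carry only nitro or hydrogen at this place on the ring. As far as these compounds go, whether an amine or a carboxylic acid there would shift the number on either core, and whether it would do so equally on both, stays open.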